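This account rests on a few compounds, and the source may have more. Where it says the series, first, only, none or still open, it means among the compounds named here.

Compound 1 `Cc1n[nH]c2c1C(c1ccc(N(C)C)cc1)C(C(N)=O)=C(N)N2` carries a primary carbamoyl group on the shared core. In a functional assay on MCF7 cells (Homo sapiens) for cytotoxicity, read by MTT assay, with a stated time of 48 h (a higher number here means a weaker inhibitor, a lower number a stronger inhibitor), compound 1 gives 4550 nM, the lowest of the three numbers recorded. Compound 2 `Cc1n[nH]c2c1C(c1ccc(N(C)C)cc1)C(C(=O)N/N=C/c1ccc(Cl)cc1)=C(N)N2` gives 25200 nM and compound 3 `Cc1n[nH]c2c1C(c1ccc(N(C)C)cc1)C(C(=O)NNc1cc([N+](=O)[O-])ccc1[N+](=O)[O-])=C(N)N2` gives 13000 nM, both higher than compound 1. Compound 4 `Cc1n[nH]c2c1C(c1ccc(N(C)C)cc1)C(C(=O)NN)=C(N)N2` is the next case: amino in place of hydrogen on an amide-type nitrogen. Within the data shown here, the one measured step bearing on this change is a 5.5-fold higher number from compound 1 to compound 2 (0.74 log units; beyond the scatter), where the amide-type nitrogen also gained a substituent; compound 3, which likewise carries a substituted amide nitrogen, sits above compound 1 as well. A shift to a higher number in this assay is therefore expected for compound 4, though smaller, since the change here is much smaller than in compound 2. The step is estimated as a 1.5-fold higher number from compound 1 to compound 4 (0.19 log units; within the scatter). Compound 4 is estimated at 7000 nM, within 3500 nM to 15000 nM.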

Compound 4, half-maximal inhibitory concentration: 42600 nM
Compound 4: the middle estimate sits 6.1-fold (0.78 log units) below what was measured, and the stated range ends below it.
By their numbers in this assay, from the lowest: compound 1; then compounds 3, 2 and 4 (each within the scatter of the next, the first and the last beyond it).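

Amino in place of hydrogen on the amide-type nitrogen, a single added nitrogen, gives a 9.4-fold higher number from compound 1 to compound 4 (0.97 log units; beyond the scatter) in this assay, so a large substituent is not needed for a shift at this position. One nitrogen atom in place of the group of 9 heavy atoms gives a 1.7-fold higher number from compound 2 to compound 4 (0.23 log units; within the scatter), which leaves the two ends unseparated. Hydrogen in place of 2,5-dinitrophenyl on the amine nitrogen gives a 3.3-fold higher number from compound 3 to compound 4 (0.52 log units; beyond the scatter), so here the aryl group goes with the lower number.

Nothing at hand accounts for these shifts. Open, from the compounds shown here alone, is how a methyl or hydroxy group on the amide-type nitrogen would read.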